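The source may report more compounds than this note shows. Statements on the series, on what has been measured and on what is new or still open speak of the compounds shown alone.

Measured so far, in a functional assay on HEK293 cells for antagonist activity at transient receptor potential cation channel subfamily V member 1 (Homo sapiens), read by calcium flux; on this read-out lower numbers stand for stronger inhibition and higher numbers for weaker inhibition:

Compound 1, `CSc1ccccc1Nc1nc2c(Nc3ccc(C(F)(F)F)cc3)ncnc2s1`: compound 1 gives 43 nM

Compound 2, `CS(=O)(=O)c1ccccc1Nc1nc2c(Nc3ccc(C(F)(F)F)cc3)ncnc2s1`: compound 2 gives 234 nM

Compound 3, `CSc1ccc(Nc2ncnc3sc(Nc4c(Cl)cccc4Cl)nc23)cc1`: compound 3 gives 96 nM

Compound 4, `CS(=O)(=O)c1ccc(Nc2ncnc3sc(Nc4c(Cl)cccc4Cl)nc23)cc1`, has not yet been measured in this assay. It shares its core with compound 3, and it relates to compound 3 in the same way that compound 2 relates to compound 1. From compound 1 to compound 2 the change is methylsulfonyl in place of methylsulfanyl on an aromatic carbon, and it made a step of a 5.4-fold higher number from compound 1 to compound 2 (0.74 log units; beyond the scatter). From compound 3 to compound 4 the change is methylsulfonyl in place of methylsulfanyl on an aromatic carbon. The two cores, that of compound 1 and that of compound 3, are not the same, and how they differ is not broken down here. The surroundings of the change also differ: in compound 1 the group sits ortho to a large group, in compound 3 it sits para to a large group, so this is the same kind of change rather than the same change. For the measured compounds named here, the only guide is the step from compound 1 to compound 2; its direction points to a weaker number for compound 4 than for compound 3, and a step near a 4.7-fold higher number from compound 3 to compound 4 (0.67 log units; beyond the scatter) is expected for compound 4, resting on a 5.4-fold higher number from compound 1 to compound 2 (0.74 log units; beyond the scatter). The different place around the change leaves room for the step to come out smaller or larger. Compound 4 is therefore expected to give about 450 nM, likely between 150 nM and 1400 nM.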

Compound 4, half-maximal inhibitory concentration: 5 nM
Beside the measured number, compound 4's estimate is 90-fold (1.95 log units) above it, outside the stated range (below it).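

In this assay, putting methylsulfonyl in place of methylsulfanyl on an aromatic carbon gave a 19-fold lower number from compound 3 to compound 4 (1.28 log units; beyond the scatter), and set beside the earlier step, this shows that the change did not carry over from one core to the other, not even in direction: the same change on two cores in this assay, a 5.4-fold higher number (0.74 log units; beyond the scatter) from compound 1 to compound 2 and a 19-fold lower number (1.28 log units; beyond the scatter) from compound 3 to compound 4, 100-fold (2.02 log units) apart, beyond the scatter of two such steps

In this series, then, the step seen on one core is no safe guide to the step on another, even when the swapped groups are the same. What this does not show is which difference decides the outcome, since the two pairs differ in their cores and also in where the group sits, and each of the two settings rests on one pair alone, so no rule for either core follows.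

On these data alone, it remains open whether the place of the group or the rest of the core governs the direction of the step, which the same swap made at both places on a single core could begin to separate. As far as these compounds go, it also remains open whether other groups in the place held by methylsulfonyl in compound 4, such as a sulfonamide, a nitrile or a carboxylic acid, would lower the number in the same way.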